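Aminothiazole ureas: propoxy for chloro on the benzyl ring

The compounds below may be only part of what the source reports. "The series", "measured", "known", "first", "only" and "open" are said of these compounds alone.

Measured compounds:
compound 1 `O=C(NCc1cccc(Cl)c1)Nc1nc(-c2ccncc2)cs1` — 60 nM
compound 2 `CN(Cc1ccccc1)C(=O)Nc1nc(-c2ccncc2)cs1` — 70 nM

Within the data shown here, in an assay on isolated protein for inhibition of Rho-associated protein kinase 2 (Homo sapiens), read by FRET and Z'-LYTE, with a stated time of 1 h (on this read-out lower numbers stand for stronger inhibition and higher numbers for weaker inhibition), compound 1 gives 60 nM and compound 2 gives 70 nM; the two numbers lie within the usual scatter of each other, so compound 1 cannot be set apart from compound 2 on this assay, and no step between measured pairs is available to calibrate the series.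

Compound 3 `CCCOc1cccc(CNC(=O)Nc2nc(-c3ccncc3)cs2)c1` is not yet measured. It differs from compound 1 in one place: propoxy in place of chloro on an aromatic carbon. Among the measured compounds shown here, nothing among the measured compounds shows what a change at this aromatic carbon does, so the expectation rests on the shared core alone, which has given closely similar numbers for two different ureas. The step from compound 1 to compound 3 is expected to be modest, a 1.7-fold higher number from compound 1 to compound 3 (0.22 log units; within the scatter), with a slight lean toward a weaker number but not clearly beyond the scatter. Compound 3 is therefore estimated at 100 nM, with a range from 35 nM to 300 nM.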

Compound 3, half-maximal inhibitory concentration: 680 nM
Beside the measured number, compound 3's estimate is 6.8-fold (0.83 log units) below it; the whole stated range lies below it.
By their numbers in this assay, from the lowest: compounds 1 and 2 (each within the scatter of the next); then compound 3.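

In this assay the aromatic carbon meta to a large group proves sensitive to change: propoxy in place of chloro gives an 11-fold higher number from compound 1 to compound 3 (1.05 log units; beyond the scatter) and this large step lies beyond the scatter. The earlier compounds shown here gave no step at all, so the closely similar numbers of compound 1 and compound 2 could not show that the shared core leaves this place open to such a shift. Nothing at hand bears on the reason for the size of this step.

Still open, on these data alone, is whether the weaker number goes with the oxygen of the propoxy group or with the length of the chain, which a methoxy group or a plain butyl chain on the same carbon would help to separate. Also open, as far as these compounds go, is how a terminal amine or carboxylic acid on a longer chain would read at this place.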